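Adding a 4-methylphenoxy end to the amine chain

This account rests on a few compounds, and the source may have more. Where it says the series, first, only, none or still open, it means among the compounds named here.

Values in a functional assay on HCT-116 cells (Homo sapiens) for antiproliferative activity, read by MTT assay, with a stated time of 48 h; a lower number here means a stronger inhibitor of growth, a higher number a weaker inhibitor of growth:
- compound 1 `Cc1ccc(-c2cnc(N(Cc3ccc(C(=O)NO)cc3)CC(C)C)s2)cc1` gives 5900 nM
- compound 2 `CCCCCCCCN(Cc1ccc(C(=O)NO)cc1)c1ncc(-c2ccc(C)cc2)s1` gives 6500 nM
- compound 3 `Cc1ccc(-c2cnc(N(CCCCOc3ccccc3)Cc3ccc(C(=O)NO)cc3)s2)cc1` gives 680 nM

Compound 1 sits level with compound 2 and well above compound 3 in this small set. The step followed here leads to compound 4 `Cc1ccc(OCCCCN(Cc2ccc(C(=O)NO)cc2)c2ncc(-c3ccc(C)cc3)s2)cc1` and is described by 3-(4-methylphenoxy)propyl in place of isopropyl on a saturated chain carbon bound to a nitrogen on an aromatic ring. Among the compounds with values here, two measured steps bear on it. A plain alkyl chain changed little, with a 1.1-fold higher number from compound 1 to compound 2 (0.04 log units; within the scatter) (heptyl in place of isopropyl). A chain ending in phenoxy counted for more, with an 8.7-fold lower number from compound 1 to compound 3 (0.94 log units; beyond the scatter) and a 9.6-fold lower number from compound 2 to compound 3 (0.98 log units; beyond the scatter) as the evidence. Within the data shown here, no measured compound carries the 4-methylphenoxy group, so its methyl remains untested. A drop of similar size to that of compound 3 is therefore expected in this assay, and the expected step is an 8.4-fold lower number from compound 1 to compound 4 (0.93 log units; beyond the scatter) (lower, beyond the scatter). The estimate for compound 4 is 700 nM (expected range 250 nM to 1900 nM).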

Compound 4, concentration for 50% growth inhibition: 580 nM
Beside the measured number, compound 4's estimate is 1.2-fold (0.08 log units) above it, within the range that was stated.
By their numbers in this assay, from the lowest: compounds 4 and 3 (each within the scatter of the next); then compounds 1 and 2 (each within the scatter of the next).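

In this assay, within the data shown here, the methyl on the phenoxy end, the one feature the earlier compounds left untested, stays within the scatter, with a 1.2-fold lower number from compound 3 to compound 4 (0.07 log units; within the scatter). The large gain over a plain alkyl chain therefore survives this methyl, as seen in a 10-fold lower number from compound 1 to compound 4 (1.01 log units; beyond the scatter) and in an 11-fold lower number from compound 2 to compound 4 (1.05 log units; beyond the scatter). Among these compounds, the two chains ending in a phenoxy group thus stand together, clearly apart from the isopropyl and heptyl groups named in the earlier steps.

No experimental evidence given here accounts for the gain in growth inhibition. On these data alone, it remains open whether the chain oxygen is needed, as a 5-phenylpentyl chain would show, and what a chlorine or methoxy on the phenoxy ring, or an amine at the chain end, would do.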